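Acetyl in place of chlorobenzoyl on the shared core

The source may hold more compounds than are shown below. What is called first, only, known or untested is meant among the compounds shown, and "the series" means these compounds.

Working notes on a small set of esters built on the shared core of compound 1 `CC1(C)S[C@@H]2/C(=C\C(=O)c3ccc(Cl)cc3)C(=O)N2[C@H]1C(=O)OC(c1ccccc1)c1ccccc1`, all read in a functional assay on A-375 cells (Homo sapiens) for cytotoxicity, read by MTT assay, with a stated time of 48 h; a higher number here means a weaker inhibitor, a lower number a stronger inhibitor. Compound 1 gives 48600 nM, the highest of the two plain numbers in this assay. Compound 2 `CC1(C)S[C@@H]2/C(=C\C(=O)OC(c3ccccc3)c3ccccc3)C(=O)N2[C@H]1C(=O)OC(c1ccccc1)c1ccccc1` gives 9100 nM, a lower number and a gap beyond the scatter. Compound 3 `CC(=O)/C=C1\C[C@H]2SC(C)(C)[C@H](C(=O)OC(c3ccccc3)c3ccccc3)N2C1=O` gives only a limit of the assay, > 100000 nM, and no number; this is the case described by the limit of > 100000 nM in this assay, at which 1 of the 3 values shown sits.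

The step to be judged leads from compound 1 to compound 4 `CC(=O)/C=C1/C(=O)N2[C@@H]1SC(C)(C)[C@@H]2C(=O)OC(c1ccccc1)c1ccccc1`, whose difference is counted as methyl in place of 4-chlorophenyl on a carbonyl carbon. No measured pair in this set carries the same change, so the size of the step is not fixed by any shown comparison. The expectation for compound 4 is a weakening, with an estimated step of a 2.1-fold higher number from compound 1 to compound 4 (0.31 log units; beyond the scatter) in this assay, because one member of the set already sits at the limit described by the limit of > 100000 nM in this assay, at which 1 of the 3 values shown sits. Compound 4 is therefore estimated at 100000 nM, within a range from 30000 nM to 300000 nM, with a fair chance that only a limit is reported.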

Compound 4, half-maximal inhibitory concentration: 63000 nM
Compound 4: the middle estimate sits 1.6-fold (0.20 log units) above what was measured; measured number inside the range.
By their numbers in this assay, from the lowest: compound 2; then compounds 1 and 4 (each within the scatter of the next). At a limit, above all of these: compound 3.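

In this assay, methyl in place of 4-chlorophenyl on a carbonyl carbon gives a 1.3-fold higher number from compound 1 to compound 4 (0.11 log units; within the scatter). For the compounds shown here, this single pair gives the first reading of this change on the shared core: removing the aromatic ring and its chlorine leaves no difference that can be told from the scatter. Compound 3 remains the only compound at a limit of the assay, which is not a number: the limit of > 100000 nM in this assay, at which 1 of the 4 values shown sits.

As far as these compounds go, whether a plain phenyl at this carbonyl carbon would read with compound 1 and compound 4, and so whether the chlorine counts apart from the ring, stays open. Also open, from the compounds shown here alone, is whether an amine or a longer chain in the same place would move the number beyond the scatter.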